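Swapping the benzothiazole for a small triazole

This account rests on a few compounds, and the source may have more. Where it says the series, first, only, none or still open, it means among the compounds named here.

Measured compounds:
Compound 1 `Cn1c(-c2ccc(NC(=O)CSc3nc4ccccc4o3)cc2)nc(-c2ccccc2)c1-c1ccccc1` gives 44.9% in a functional assay on HT-29 cells (Homo sapiens) for cytotoxicity, read by MTT assay, with a stated time of 24 h, tested at 6.4 ug/mL; a higher number here means a stronger effect of the compound at the concentration tested, a lower number a weaker effect.
Compound 2 `Cn1c(-c2ccc(NC(=O)CSc3nc4cc(Cl)ccc4o3)cc2)nc(-c2ccccc2)c1-c1ccccc1` gives 29.4% in this assay.
Compound 3 `Cn1c(-c2ccc(NC(=O)CSc3nc4ccccc4s3)cc2)nc(-c2ccccc2)c1-c1ccccc1` gives 36.8% in this assay.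

Compound 3 stands second highest of these three numbers. Its nearest neighbour is compound 2, a step that is a number 7.4 percentage points higher from compound 2 to compound 3 (within the scatter); its furthest is compound 1, a step that is a number 8.1 percentage points lower from compound 1 to compound 3 (within the scatter). Both lie within the usual scatter, so the three compounds cannot be ordered with confidence, apart from the step of a number 15.5 percentage points lower from compound 1 to compound 2 (beyond the scatter), which is the only one beyond the scatter.

Compound 4 `Cn1cnnc1SCC(=O)Nc1ccc(-c2nc(-c3ccccc3)c(-c3ccccc3)n2C)cc1` has not yet been measured. It differs from compound 3 in one place: 4-methyl-4H-1,2,4-triazol-3-yl in place of 1,3-benzothiazol-2-yl on a sulfur. Among the compounds with values here, no measured step covers a change of this kind; the closest, a number 8.1 percentage points lower from compound 1 to compound 3 (within the scatter), changed only one atom within the same group and stayed within the scatter. The new group is smaller and carries one more acceptor, so the outcome is open. A modest drop is expected, a number 8.8 percentage points lower from compound 3 to compound 4 (within the scatter), with wide uncertainty. Compound 4 is therefore estimated at 28%, between 10% and 45%.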

Compound 4, a percentage reported as activity, at one concentration (the size of the read-out at that concentration, not a potency): 43.1%
Compound 4: the middle estimate sits 15.1 percentage points below what was measured; the range from low to high includes it.
By their numbers in this assay, from the lowest: compounds 2, 3, 4 and 1 (each within the scatter of the next, the first and the last beyond it).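

On the sulfur, a single five-membered ring can stand where the two-ring groups stood: the 4-methyl-4H-1,2,4-triazol-3-yl group gives a number 6.3 percentage points higher from compound 3 to compound 4 (within the scatter) and a number 1.8 percentage points lower from compound 1 to compound 4 (within the scatter) in this assay, so this much smaller group, with its extra acceptor, cannot be told apart from either unchlorinated two-ring group. Against the 5-chloro-1,3-benzoxazol-2-yl group, the same replacement gives a number 13.7 percentage points higher from compound 2 to compound 4 (beyond the scatter) and so separates compound 4 from compound 2, just as compound 1 is separated from it. Nothing measured here explains why the read-out holds with so much of the group removed.

As far as these compounds go, whether the sulfur needs an aromatic ring at all remains open, since a simple amine or a carboxylic acid at the end of a short chain could show how much of this group matters. The compounds shown also leave open whether the methyl on the triazole contributes, and each figure, taken at one concentration, describes the size of an effect rather than a potency.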